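This account rests on a few compounds, and the source may have more. Where it says the series, first, only, none or still open, it means among the compounds named here.

Among the compounds with values here, in a functional assay on HL-60 cells (Homo sapiens) for cytotoxicity, read by MTT assay, with a stated time of 72 h (a lower number here means a stronger inhibitor, a higher number a weaker inhibitor), two compounds built on one shared core have numbers so far. Compound 1 `Cc1ccc(/N=C2\C=C(OCc3cn(S(=O)(=O)c4ccc(C)cc4)nn3)C(=O)c3ccccc32)cc1` gives 5420 nM, and compound 2 `COc1ccc(/N=C2\C=C(OCc3cn(S(=O)(=O)c4ccc(C)cc4)nn3)C(=O)c3ccccc32)cc1` gives 6960 nM. The step between them, a 1.3-fold higher number from compound 1 to compound 2 (0.11 log units; within the scatter), lies within the scatter, so these numbers do not separate compound 2 from compound 1.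

Compound 3 `Cc1ccc(S(=O)(=O)n2cc(COC3=C/C(=N\c4ccc(Cl)cc4)c4ccccc4C3=O)nn2)cc1` keeps the shared core and differs from compound 2 in one group: chloro in place of methoxy on an aromatic carbon. Chloro takes the place of methoxy on an aromatic carbon, para to a large group, so 4-methoxyphenyl becomes 4-chlorophenyl. Within the data shown here, no chloro compound has been measured yet. Among the measured compounds shown here, the only evidence that bears on this change is the exchange of methyl for methoxy, a 1.3-fold higher number from compound 1 to compound 2 (0.11 log units; within the scatter), and it gives no direction to follow. On that single small step, no shift beyond the scatter is expected in this assay, though one step is thin evidence for a new group. The expected change is a 1.2-fold lower number from compound 2 to compound 3 (0.06 log units; within the scatter). For compound 3 the estimate is 6000 nM, with an expected range of 2500 nM to 13000 nM.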

Compound 3, half-maximal inhibitory concentration: 6920 nM
The estimate for compound 3 lay 1.2-fold (0.06 log units) below the measured number; the range from low to high includes it.
By their numbers in this assay, from the lowest: compounds 1, 3 and 2 (each within the scatter of the next).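

In this assay, chloro in place of methoxy on this aromatic carbon, para to a large group, gives a 1.0-fold lower number from compound 2 to compound 3 (0.00 log units; within the scatter), and chloro in place of methyl at the same place gives a 1.3-fold higher number from compound 1 to compound 3 (0.11 log units; within the scatter). The position has now carried three different groups, and neither new step separates chloro from the group it replaces, although the change from methoxy to chloro takes away a hydrogen-bond acceptor and leaves a single heavy atom in place of two. No independent measurement is available that could account for these numbers.

On these data alone, all three compounds carry a single methyl, methoxy or chloro group at this position, so it remains open whether an amine, a carboxylic acid or a longer chain there would also stay within the scatter of these numbers. The rest of the shared core is identical across compound 1, compound 2 and compound 3, so they also leave open how a change anywhere else in the structure would read in this assay.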